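Alkyl substitution on the chain carbon of compound 1

A few compounds are considered here, and "the series" means these few. Any claim that something is new, unique, unknown or untested is made for them only; others in the source may bear on it.

Compound 1 `COc1cccc2cc(C(=O)NCNC(=O)CCN(O)C=O)oc12` carries hydrogen on the chain carbon next in line to the amide carbonyl. Going by the values given here, in an assay on CHO cells for inhibition of bone morphogenetic protein 1 (Homo sapiens), with stated times of 10 min and 60 min (a lower number here means a stronger inhibitor, a higher number a weaker inhibitor), compound 1 gives 6300 nM, the highest of the two numbers known so far. Among the compounds with values here, its only neighbour is compound 2 `COc1cccc2cc(C(=O)NCNC(=O)[C@H](Cc3ccccc3)CN(O)C=O)oc12`, which in this assay gives 160 nM; the single change between them, a benzyl group entering where compound 1 carries hydrogen, produced a 39-fold lower number from compound 1 to compound 2 (1.60 log units; beyond the scatter).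

Compound 3 `CCCCC[C@@H](CN(O)C=O)C(=O)NCNC(=O)c1cc2cccc(OC)c2o1` has not yet been measured. It differs from compound 1 as pentyl in place of hydrogen on a saturated chain carbon bound to a carbonyl carbon and a saturated chain carbon, the same place where compound 2 carries benzyl. The step from compound 1 to compound 2 is the only one that bears on this change, and it was large and well beyond the scatter. Within the data shown here, a pentyl chain at this place is therefore expected to lower the number in this assay by a large margin, with some uncertainty since the entering group has no ring and only one measured step exists. Compound 3 is expected at 320 nM, within 80 nM to 1300 nM. This corresponds to an expected 20-fold lower number from compound 1 to compound 3 (1.29 log units; beyond the scatter).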

Compound 3, half-maximal inhibitory concentration: 4000 nM
Estimate against measurement, compound 3: 13-fold (1.10 log units) below; measured number outside the range, above it.
By their numbers in this assay, from the lowest: compound 2; then compounds 3 and 1 (each within the scatter of the next).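

In this assay, a 1.6-fold lower number from compound 1 to compound 3 (0.20 log units; within the scatter), so pentyl in place of hydrogen on this saturated chain carbon gives a number that cannot be separated from that of compound 1. The large step seen with benzyl therefore does not extend to every carbon substituent at this place: compound 2 gives 160 nM, while compound 3 gives 4000 nM and stays with compound 1 in the same band. Occupying the place with a carbon group of this size is thus not sufficient on its own to reproduce the result of compound 2, and no measurement to hand accounts for the contrast between benzyl and pentyl.

The compounds shown leave open whether a cyclohexylmethyl group, which keeps a ring on a single chain carbon but is not aromatic, would stand with compound 2 or with compound 3, and whether a shorter chain such as propyl or isobutyl would behave as pentyl does. Also open, on these data alone, is how a chain ending in an amine or a carboxylic acid would read at this same place.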